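This account rests on a few compounds, and the source may have more. Where it says the series, first, only, none or still open, it means among the compounds named here.

Compound 3 `CC(C)(C)OC(=O)Nc1ncc(C(Oc2ccc(Br)cc2)c2ccc(Cl)cc2)s1` is one of three compounds that have been tested in an ADME assay on HepG2 2.2.15 cells (Homo sapiens) for cytotoxicity; a lower number here means that less compound is tolerated, a higher number that more compound is tolerated. In this assay compound 3 gives > 50000 nM, which is a limit of the measurement rather than a number. Compound 1 `O=C(Nc1ncc(Cc2ccc(F)cc2)s1)C1CCCCC1` gives > 50000 nM in this assay, again a limit. Compound 2 `O=C(Nc1ncc(Cc2ccc(Br)cc2)s1)c1cccs1` gives > 50000 nM in this assay, also a limit. Compound 3 therefore stands exactly where the other two stand: all three reach (the limit of > 50000 nM in this assay, at which 3 of the 3 values shown sit), and none of them yields a number that could be compared. No two of these compounds differ in only one place, so no step between measured compounds can be read off.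

Compound 4 `Cc1cc(Br)cc(OC(c2ccc(Cl)cc2)c2cnc(NC(=O)OC(C)(C)C)s2)c1` has not yet been measured. It differs from compound 3 in a single place: 3-bromo-5-methylphenyl in place of 4-bromophenyl on an oxygen on a saturated carbon. In words, 3-bromo-5-methylphenyl takes the place of 4-bromophenyl on an oxygen on a saturated carbon. Because every value shown sits at the limit of > 50000 nM in this assay, at which 3 of the 3 values shown sit, the measured compounds give no direction for this change. The step from compound 3 to compound 4 is expected to be a step that the limit leaves unreadable from compound 3 to compound 4, which is to say no change beyond the usual scatter. Compound 4 is expected at about 60000 nM, between 30000 nM and 150000 nM, and will most probably be reported only as a limit in this assay.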

Compound 4, half-maximal cytotoxic concentration: > 50000 nM
Compound 4 ended at the assay's limit (the forecaster's own chance of this, stated with the estimate: 80%); the middle value is on the limit's open side.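

No step can be read from compound 3 to compound 4 in this assay, since both compounds end at a limit rather than at a number: the limit of > 50000 nM in this assay, at which 4 of the 4 values shown sit. The compounds shown leave open how 3-bromo-5-methylphenyl and 4-bromophenyl compare beyond that limit, and whether any change to these compounds would bring a measurable number in this read-out.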